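Piperazine nitrogen substituents on an aminothiophene ketone series

This account rests on a few compounds, and the source may have more. Where it says the series, first, only, none or still open, it means among the compounds named here.

Measured compounds:
compound 1 `CC(C)N1CCN(Cc2csc(N)c2C(=O)c2ccc(Cl)cc2)CC1` gives -7.4%
compound 2 `Nc1scc(CN2CCN(c3cc(Cl)cc(Cl)c3)CC2)c1C(=O)c1ccc(Cl)cc1` gives -74%
compound 3 `Nc1scc(CN2CCN(C3CCCCCC3)CC2)c1C(=O)c1ccc(Cl)cc1` gives -25%

In a functional assay on CHO cells with adenosine receptor A1 (Homo sapiens) as the target, read by cAMP accumulation and immunoassay, with a stated time of 6 min, tested at 10 uM (on this read-out higher numbers stand for a weaker effect at the one concentration tested and lower numbers for a stronger effect), compound 2 stands lowest of the three numbers; the nearest is compound 3, then compound 1, both beyond the scatter. The step to compound 4 `Nc1scc(CN2CCN(CCCc3ccc(Cl)cc3)CC2)c1C(=O)c1ccc(Cl)cc1` is 3-(4-chlorophenyl)propyl in place of 3,5-dichlorophenyl on an amine nitrogen in a ring. Among the measured compounds shown here, no measured step swaps an aryl on that nitrogen for an aryl-bearing chain. The nearest comparisons are a number 49 percentage points higher from compound 2 to compound 3 (beyond the scatter) and a number 66.6 percentage points lower from compound 1 to compound 2 (beyond the scatter), which show the group directly on the ring nitrogen matters greatly, with the two alkyl groups sitting well above the aryl. Compound 4 carries an alkyl chain at that nitrogen, so a step upward, large, is expected: a number 44 percentage points higher from compound 2 to compound 4 (beyond the scatter). Compound 4 is estimated at -30%, in the range -65% to 5%.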

Compound 4, a percentage reported as activity, at one concentration (the size of the read-out at that concentration, not a potency): -76%
The estimate for compound 4 lay 46 percentage points above the measured number, and the stated range ends above it.
By their numbers in this assay, from the lowest: compounds 4 and 2 (each within the scatter of the next); then compound 3; then compound 1.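

In this assay the aromatic ring can sit on a propyl chain rather than directly on the ring nitrogen without a change beyond the scatter (a number 2 percentage points lower from compound 2 to compound 4 (within the scatter)). Compound 4 also stands apart from the compounds bearing cycloheptyl (a number 51 percentage points lower from compound 3 to compound 4 (beyond the scatter)) and isopropyl (a number 68.6 percentage points lower from compound 1 to compound 4 (beyond the scatter)), so across these four compounds the split follows the presence of an aromatic ring on the substituent, not the direct attachment of that ring to the nitrogen. Nothing at hand explains this result.

The compounds shown leave open whether a benzyl or phenethyl linker would fit the same pattern. They also leave open whether a pyridyl ring or an unsubstituted phenyl could replace the chlorinated aromatic rings.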